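A few compounds are considered here, and "the series" means these few. Any claim that something is new, unique, unknown or untested is made for them only; others in the source may bear on it.

Measured in a functional assay on the whole organism for inhibition, with Rattus norvegicus as the target; a higher number here means that more compound is needed for the effect, a lower number that less compound is needed:
- Compound 1 `CC(C)c1ccc(OC(Cc2ccccc2)C(=O)O)cc1`: 50 mg/kg
- Compound 2 `CC(C)c1ccc(OC(C)(Cc2ccccc2)C(=O)O)cc1`: > 10 mg/kg
- Compound 3 `CC(C)c1ccc(OC(C)(Cc2ccc(C(C)(C)C)cc2)C(=O)O)cc1`: 5 mg/kg

Compound 2 is known only through a limit, > 10 mg/kg, and that is not a number. Compound 4 `COc1ccccc1CC(C)(Oc1ccc(C(C)C)cc1)C(=O)O` differs from it by methoxy in place of hydrogen on an aromatic carbon, ortho to a large group, so phenyl becomes 2-methoxyphenyl.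

The closest measured change is tert-butyl in place of hydrogen on an aromatic carbon, which gives an at least 2.0-fold lower number from compound 2 to compound 3 (0.30 log units; that floor lies within the scatter). It involves a different group, and its size is only a floor. The other measured change, a step that the limit leaves unreadable from compound 1 to compound 2, puts methyl on a saturated chain carbon and offers no size to carry over. Neither gives firm grounds for a shift in this assay, so no step beyond the scatter is expected.

The expected change is a step that the limit leaves unreadable from compound 2 to compound 4. For compound 4 the estimated value is 15 mg/kg, with an expected range of 5 mg/kg to 50 mg/kg.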

Compound 4, dose for half-maximal effect: > 10 mg/kg
Compound 4 was reported as a limit; the forecaster's own chance of this, stated with the estimate: 30%; the middle value does not contradict the limit.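

No size can be read for the step between compound 2 and compound 4, because both are known only through the same limit, and a limit is not a number: the limit of > 10 mg/kg in this assay, at which 2 of the 4 values shown sit.

Going by these compounds, how much the methoxy on the aromatic carbon changes the dose needed, or whether it changes it at all, stays open.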